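The source may report more compounds than this note shows. Statements on the series, on what has been measured and on what is new or still open speak of the compounds shown alone.

In an ADME assay on H9c2 cells (Rattus norvegicus) for cytotoxicity, read by resazurin assay, with a stated time of 72 h (on this read-out lower numbers stand for higher toxicity in this test and higher numbers for lower toxicity in this test), three compounds sharing one core have been measured so far. Compound 1 `C/C(=N\Nc1nc(C)cs1)c1ccc(Cl)c(Cl)c1` gives 26100 nM, and compound 2 `C/C(=N\Nc1nc(-c2ccncc2)cs1)c1ccc(Cl)c(Cl)c1` gives 41900 nM. The step between them is a 1.6-fold higher number from compound 1 to compound 2 (0.21 log units; within the scatter).

Compound 3 `C/C(=N\Nc1nc(-c2ccc(C)cc2)cs1)c1ccc(Cl)c(Cl)c1` gives > 50000 nM, which is a limit of the assay and not a number. Its standing therefore rests on a floor alone, and the steps that reach it are an at least 1.9-fold higher number from compound 1 to compound 3 (0.28 log units; that floor lies within the scatter) and an at least 1.1-fold higher number from compound 2 to compound 3 (0.07 log units; that floor lies within the scatter).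

Compound 4 `C/C(=N\Nc1nc(-c2ccc(F)cc2)cs1)c1ccc(Cl)c(Cl)c1` differs from compound 3 by fluoro in place of methyl on an aromatic carbon, para to a large group. For the measured compounds named here, no measured step makes this exact change. The nearest evidence is the replacement of the whole group on the core, as in an at least 1.1-fold higher number from compound 2 to compound 3 (0.07 log units; that floor lies within the scatter), whose floor lies within the scatter. On that basis, no step beyond the scatter is expected in this assay.

The expected step is an at least 1.1-fold lower number from compound 3 to compound 4 (0.04 log units; that floor lies within the scatter). Compound 4 is estimated at 45000 nM, with an expected range from 22000 nM to 90000 nM.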

Compound 4, half-maximal cytotoxic concentration: > 50000 nM
Compound 4 gave a limit, no number; the forecaster's own chance of this, stated with the estimate: 50%; at least 1.1-fold (0.04 log units) between middle value and limit.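

In this assay compound 4 gives a limit of the assay and not a number, as compound 3 does, so the step from methyl to fluoro on this aromatic carbon cannot be read. What the result adds is that a second para-substituted phenyl group on the shared core, 4-fluorophenyl alongside 4-methylphenyl, ends at the same limit: the limit of > 50000 nM in this assay, at which 2 of the 4 values shown sit. The two steps that can be read are an at least 1.9-fold higher number from compound 1 to compound 4 (0.28 log units; that floor lies within the scatter) and an at least 1.1-fold higher number from compound 2 to compound 4 (0.07 log units; that floor lies within the scatter), and neither separates the compounds beyond the scatter.

From the compounds shown here alone, how far compound 3 and compound 4 lie past the limit, and whether they differ at all, stays open. Also open, going by these compounds, is whether an amine or a carboxylic acid in place of the fluoro would bring the number back within the range of the assay.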